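This account rests on a few compounds, and the source may have more. Where it says the series, first, only, none or still open, it means among the compounds named here.

Measured compounds:
compound 1 `CCC(C(=O)N1CCN(c2cccc(Cl)c2)CC1)N1C(=O)CCC1=O` — 25%
compound 2 `CC(C(=O)N1CCN(c2ccccc2C(F)(F)F)CC1)N1C(=O)CCC1=O` — 75%
compound 3 `CC(C(=O)N1CCN(c2cccc(Cl)c2)CC1)N1C(=O)CCC1=O` — 50%

All three were tested in a functional assay on the whole organism (strain Swiss) with Mus musculus as the target, in the maximal electroshock model, with a stated time of 2 h, at a dose of 300 mg/kg by the intraperitoneal route; a lower number here means a weaker effect, a higher number a stronger effect of the compound at the dose given. Among them compound 1 stands lowest: compound 3 lies nearer to it, compound 2 furthest away, and both gaps are beyond the usual scatter of this assay. Among the measured compounds shown here, only one pair differs in a single place, compound 1 and compound 3, where a hydrogen replaces a methyl on a saturated chain carbon, two bonds along the chain from an amide-type nitrogen in a ring and a carbonyl carbon; that step gave a number 25 percentage points higher from compound 1 to compound 3 (beyond the scatter). Compound 2 and compound 3 differ in the substituted aromatic ring, and their values simply show compound 2 higher.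

Compound 4 `CCC(C(=O)N1CCN(c2cccc(OC)c2)CC1)N1C(=O)CCC1=O` has not yet been measured. It differs from compound 1 as follows: methoxy in place of chloro on an aromatic carbon. For the measured compounds named here, none of the measured steps touches this part of the molecule, so the measured data give no guide to the size or direction of the change, and the working expectation is a step within the scatter.

For compound 4 the expected value is 30%, within a range from 0% to 60%. That corresponds to an expected step of a number 5 percentage points higher from compound 1 to compound 4 (within the scatter).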

Compound 4, a percentage reported as activity, at one dose (the size of the read-out at that dose, not a potency): 0%
The estimate for compound 4 lay 30 percentage points above the measured number; low and high end bracket the measured number.
By their numbers in this assay, from the lowest: compound 4; then compound 1; then compound 3; then compound 2.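

In this assay, changing 3-chlorophenyl to 3-methoxyphenyl gave a number 25 percentage points lower from compound 1 to compound 4 (beyond the scatter), which shows that the group at this aromatic position can move the read-out by more than the usual scatter. Among the compounds shown here, the only earlier single-place step, a number 25 percentage points higher from compound 1 to compound 3 (beyond the scatter), lay on the saturated chain, so this is the first measured sign that the aromatic ring substituent matters as well, and here the number goes down rather than up. No available measurement bears on what lies behind this drop.

As far as these compounds go, a single replacement at this position cannot show how other groups would behave there, so it remains open whether an amine, a carboxylic acid or a plain methyl would give a number nearer to that of compound 4 or to that of compound 1. From the compounds shown here alone, it also remains open whether the change from chloro to methoxy would lower the number by a similar amount on the chain of compound 3, which would show whether the two changes act independently.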